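The source may report more compounds than this note shows. Statements on the series, on what has been measured and on what is new or still open speak of the compounds shown alone.

Series notes. Going by the values given here, compound 1 `Cc1nccn1-c1cnc(NCc2c(F)ccc3c2CCO3)c2cn[nH]c(=O)c12` gives 2.1 in a physicochemical assay for lipophilicity, using the shake flask method, in phosphate buffer, measured as octanol-water partition, with a stated time of 30 min, at pH 7.4 (on this read-out lower numbers stand for lower lipophilicity and higher numbers for higher lipophilicity), the lower of the two numbers measured so far. Among the compounds with values here, compound 2 `Cc1ncccc1-c1cnc(NCc2c(F)ccc3c2CCO3)n2c(=O)[nH]nc12` gives 3 in this assay, a gap beyond the usual scatter; no single-point step links these two. Compound 3 `Cc1ncccc1-c1cnc(NCc2c(F)ccc3c2CCO3)c2cn[nH]c(=O)c12` is not yet measured. Its change from compound 1 is 2-methylpyridin-3-yl in place of 2-methyl-1H-imidazol-1-yl on an aromatic carbon, on an aromatic carbon of the shared core. Within the data shown here, no measured step covers this exact change, so the expected size rests on the two values shown. An increase is expected, estimated as a number 0.70 log units higher from compound 1 to compound 3 (beyond the scatter). Compound 3 is expected to give about 2.8, in the range 2.3 to 3.3.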

Compound 3, distribution coefficient: 3
Estimate against measurement, compound 3: 0.20 log units below, and the stated range covers the measured number.
By their numbers in this assay, from the lowest: compound 1; then compounds 2 and 3 (each within the scatter of the next).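

On the aromatic carbon of the shared core, two atoms from the ring nitrogen, 2-methylpyridin-3-yl in place of 2-methyl-1H-imidazol-1-yl gives a number 0.90 log units higher from compound 1 to compound 3 (beyond the scatter) in this assay. Going by these compounds alone, this is the only single-point step so far, and it shows that this position alone can move the read-out with the rest of the structure held constant. No evidence at hand bears on why the step arises.

On these data alone, whether the same change carries over to the core of compound 2 remains open. Also open, as far as these compounds go, is how an amine or a carboxylic acid on this aromatic carbon would read in this assay.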